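This account rests on a few compounds, and the source may have more. Where it says the series, first, only, none or still open, it means among the compounds named here.

Of the compounds shown here, two carrying the shared core have been measured so far. Compound 1, `NCCCc1c[nH]c2c(F)cccc12`, gives 24 nM in an assay on isolated protein (urine) for inhibition of Myeloperoxidase (Homo sapiens), with a stated time of 5 min; on this read-out lower numbers stand for stronger inhibition and higher numbers for weaker inhibition. Compound 2, `N#CCCCc1c[nH]c2ccc(F)cc12`, gives 63 nM in this assay. Of these two numbers, compound 2 has the higher one, meaning the weaker inhibition, and the gap between compound 2 and compound 1 lies beyond the usual scatter of repeated measurements.

Compound 3, `N#CSCCCc1c[nH]c2ccc(F)cc12`, has not yet been measured in this assay. It differs from compound 2 in one place: cyanosulfanyl in place of cyano on a saturated chain carbon, three bonds along the chain from an aromatic carbon. For the measured compounds named here, no comparable step between two measured compounds is available, so there is nothing in the measured data that calibrates the effect of inserting a sulfur between the chain and the nitrile.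

In the absence of such a reference, the step from compound 2 to compound 3 is expected to be a 1.1-fold lower number from compound 2 to compound 3 (0.06 log units; within the scatter), that is, no change beyond the scatter in either direction. Compound 3 is accordingly estimated to give 55 nM in this assay, with a range from 15 nM to 200 nM.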

Compound 3, half-maximal inhibitory concentration: 5 nM
Compound 3: the middle estimate sits 11-fold (1.04 log units) above what was measured, and the stated range ends above it.
By their numbers in this assay, from the lowest: compound 3; then compound 1; then compound 2.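

In this assay, cyanosulfanyl in place of cyano on a saturated chain carbon, three bonds along the chain from an aromatic carbon, gives a 13-fold lower number from compound 2 to compound 3 (1.10 log units; beyond the scatter) and so produces a large step beyond the scatter. This shows that the group carried at this place on the chain can change the inhibition read-out substantially, even though the nitrile remains and the visible change is the addition of one sulfur. The earlier compounds could not show this, as they differed in more than one place and offered no single-change step, and no outside measurement available here accounts for the size of this one.

Going by these compounds, it remains open whether the sulfur can do without the nitrile, which a thiol or a methylsulfanyl group at the same place would test, or whether a different atom in the sulfur's place, such as oxygen, gives a similar step. The data also leave open whether the step carries over to a shorter or longer chain, or to a core with its fluorine placed as in compound 1.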